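Trimming the cinnamate ester of compound 1 to an acetate

This account rests on a few compounds, and the source may have more. Where it says the series, first, only, none or still open, it means among the compounds named here.

Of the compounds shown here, three of one shared core have been tested in a functional assay on A549 cells (Homo sapiens) for antiproliferative activity, read by MTT assay, with a stated time of 6 days; on this read-out lower numbers stand for stronger inhibition and higher numbers for weaker inhibition. Compound 1 `O=C1C=C[C@@H](OCc2ccccc2)[C@@H]([C@@H](COC(=O)/C=C/c2ccccc2)OCc2ccccc2)O1` gives 13300 nM, the highest number of the three. Compound 3 `CC(=O)OC[C@@H](OC(C)=O)[C@H]1OC(=O)C=C[C@H]1OC(C)=O` gives 12600 nM, which sits within the usual scatter of compound 1, so the two cannot be ordered. Compound 2 `CC(=O)O[C@@H]1C=CC(=O)O[C@@H]1[C@@H](COC(=O)/C=C/c1ccc(F)cc1)OC(C)=O` gives 2120 nM, a clearly lower number than compound 1.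

Compound 4 `CC(=O)OC[C@@H](OCc1ccccc1)[C@H]1OC(=O)C=C[C@H]1OCc1ccccc1` keeps the two benzyl ethers of compound 1 and changes only the ester on the side chain: methyl in place of 2-phenylethenyl on a carbonyl carbon. Among the measured compounds shown here, one measured step bears directly on this kind of change. Going from compound 2 to compound 3, the same swap of a substituted ethenylphenyl group for a methyl on the carbonyl carbon gave a 5.9-fold higher number from compound 2 to compound 3 (0.77 log units; beyond the scatter), a loss of potency. By that precedent, compound 4 is expected to show a step of about a 3.4-fold higher number from compound 1 to compound 4 (0.53 log units; beyond the scatter) in this assay, toward weaker inhibition. Compound 4 is therefore estimated at 45000 nM, with a likely range from 15000 nM to 150000 nM.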

Compound 4, half-maximal inhibitory concentration: 15000 nM
Compound 4: the middle estimate sits 3.0-fold (0.48 log units) above what was measured; low and high end bracket the measured number.
By their numbers in this assay, from the lowest: compound 2; then compounds 3, 1 and 4 (each within the scatter of the next).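

In this assay, methyl in place of 2-phenylethenyl on the carbonyl carbon gives a 1.1-fold higher number from compound 1 to compound 4 (0.05 log units; within the scatter), so with the two benzyl ethers on the shared core, the cinnamate ester can be trimmed to an acetate without a readable change. The earlier step of the same kind, a 5.9-fold higher number from compound 2 to compound 3 (0.77 log units; beyond the scatter), is beyond the scatter, but that pair carries acetates where these compounds carry benzyl ethers, and its phenyl ring bears a fluorine, so this swap does not have one fixed size across the series. Nothing measured here accounts for that difference.

The compounds shown leave open whether the ethers or the fluorine sets the gap between the two steps. They also leave open how a benzoyl or a longer butanoyl group on this carbonyl carbon would compare.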